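The compounds below may be only part of what the source reports. "The series", "measured", "known", "first", "only" and "open" are said of these compounds alone.

Measured so far:
- compound 1 `CCOC(CC(=O)O)c1ccc(OCC2COc3ccc(Cl)cc3O2)cc1` gives 640 nM in a functional assay on HEK293 cells for agonist activity at Free fatty acid receptor 1 (Homo sapiens), read by fluorescence and calcium flux, with a stated time of 10 min; on this read-out lower numbers stand for an effect already at smaller amounts and higher numbers for an effect only at larger amounts of compound
- compound 2 `Cn1nncc1C(CC(=O)O)c1ccc(OCC2COc3ccc(Cl)cc3O2)cc1` gives 3870 nM in this assay

Within the data shown here, compound 2 stands at the higher of the two numbers recorded in this assay; its only neighbour is compound 1, and the single measured step is a 6.0-fold higher number from compound 1 to compound 2 (0.78 log units; beyond the scatter), which replaces the ethoxy group by the triazolyl ring on the saturated chain carbon.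

Compound 3 `Cn1cncc1C(CC(=O)O)c1ccc(OCC2COc3ccc(Cl)cc3O2)cc1` is not yet measured. It differs from compound 2 by 1-methyl-1H-imidazol-5-yl in place of 1-methyl-1H-1,2,3-triazol-5-yl on a saturated chain carbon bound to an aromatic carbon and a saturated chain carbon, a swap of one five-membered azole for another at the same place. Among the measured compounds shown here, no measured step in this assay covers an exchange between two such rings; the one step available, from an ethoxy group to the triazolyl ring, describes a different kind of change and gives no direct guide. The two azoles match in size and in the absence of donors, differing only in the count of ring nitrogens and acceptors. On that basis compound 3 is expected to land near compound 2, with a step of a 1.1-fold lower number from compound 2 to compound 3 (0.04 log units; within the scatter) that is expected not to exceed the scatter. For compound 3 the estimated value in this assay is 3500 nM, with an expected range from 1200 nM to 10000 nM.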

Compound 3, half-maximal effective concentration: 3060 nM
Beside the measured number, compound 3's estimate is 1.1-fold (0.06 log units) above it; low and high end bracket the measured number.
By their numbers in this assay, from the lowest: compound 1; then compounds 3 and 2 (each within the scatter of the next).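

In this assay, 1-methyl-1H-imidazol-5-yl in place of 1-methyl-1H-1,2,3-triazol-5-yl on the saturated chain carbon gives a 1.3-fold lower number from compound 2 to compound 3 (0.10 log units; within the scatter) and so does not separate the two azoles, even though they differ in their counts of ring nitrogens and hydrogen-bond acceptors. Ethoxy replaced by the imidazolyl ring gives a 4.8-fold higher number from compound 1 to compound 3 (0.68 log units; beyond the scatter) and by the triazolyl ring gives a 6.0-fold higher number from compound 1 to compound 2 (0.78 log units; beyond the scatter) in the same assay, so both azoles read beyond the scatter on the higher side of ethoxy, and neither goes against this within the three compounds. No measurement at hand explains this difference between ethoxy and the two rings.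

The compounds shown leave open whether a phenyl ring, with no ring nitrogen, or an azole without its methyl group would behave like these two azoles at this place. Also open, as far as these compounds go, is how a methoxy group, a longer propoxy chain or an amine such as dimethylamino would read against ethoxy on the same carbon of the shared core.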